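This account rests on a few compounds, and the source may have more. Where it says the series, first, only, none or still open, it means among the compounds named here.

Compound 1, `C[C@@H](O)[C@H](NC(=O)CN(c1nc(Cl)nc2[nH]cnc12)C1CC1)C(=O)O`: 37.6%
Compound 2, `CC[C@H](C)[C@H](NC(=O)CN(c1nc(Cl)nc2[nH]cnc12)C1CC1)C(=O)OCc1ccccc1`: 22%
Compound 3, `CSCC[C@H](NC(=O)CN(c1ncnc2c1ncn2C1CCCCO1)C1CC1)C(=O)OCc1ccccc1`: 28.7%

In a functional assay on the whole organism (Tail, strain ICR) with Mus musculus as the target, in the tail flick test, with a stated time of 120 min, at a dose of 25 umol/kg by the oral route (a lower number here means a weaker effect, a higher number a stronger effect of the compound at the dose given), compound 1 gives 37.6%, the largest of the three numbers. Its difference from compound 3, which gives 28.7%, lies within the scatter of this kind of measurement, so the two cannot be ordered; its difference from compound 2, which gives 22%, lies beyond the scatter. For the measured compounds named here, no two of the measured compounds differ in a single place, so no step between them is available to guide expectation.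

Compound 4, `N=C(N)NCCC[C@H](NC(=O)CN(c1nc(Cl)nc2[nH]cnc12)C1CC1)C(=O)O`, has not been measured. It differs from compound 1 in one place: a group of 7 heavy atoms (4 carbon, 3 nitrogen; no ring) in place of a group of 3 heavy atoms (2 carbon, 1 oxygen; no ring), on a saturated chain carbon bound to an amide-type nitrogen and a carbonyl carbon. The 1-hydroxyethyl group leaves from the saturated chain carbon bound to an amide-type nitrogen and a carbonyl carbon.

Going by the values given here, with no comparable step among the measured compounds, the expectation is a step in this assay no larger than the scatter, slightly upward if anything. Compound 4 is expected to give 40%, within a range from 20% to 60%, which means an expected step of a number 2.4 percentage points higher from compound 1 to compound 4 (within the scatter).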

Compound 4, a percentage reported as activity, at one dose (the size of the read-out at that dose, not a potency): 17%
Compound 4: middle estimate off by 23 percentage points, on the high side; measured number outside the range, below it.
By their numbers in this assay, from the lowest: compounds 4, 2, 3 and 1 (each within the scatter of the next, the first and the last beyond it).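

For the compounds shown here, this pair is the first comparison that differs in a single place. In this assay, it shows that the saturated chain carbon bound to an amide-type nitrogen and a carbonyl carbon is sensitive to its substituent: replacing 1-hydroxyethyl with the group of 7 heavy atoms (4 carbon, 3 nitrogen; no ring) gives a number 20.6 percentage points lower from compound 1 to compound 4 (beyond the scatter) at this dose. With only this one pair, the larger size of the entering group cannot be separated from its greater number of hydrogen-bond donors, and no measurement shown accounts for the lower number.

Going by these compounds, it remains open whether a simple methyl group or a chain ending in a plain amine at this carbon would stay close to compound 1 or fall toward compound 4. Whether the same replacement would have a similar effect on the core of compound 3 is also unresolved.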